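Replacing 6-methoxypyridin-3-yl with 1,3-benzoxazol-5-yl in compound 4

A few compounds are considered here, and "the series" means these few. Any claim that something is new, unique, unknown or untested is made for them only; others in the source may bear on it.

Of the compounds shown here, three built on a shared core have been measured so far in an ADME assay (liver) for metabolic stability, with Liver microsome (Rattus norvegicus) as the target, using microsomes and NADPH, with a stated time of 30 min, tested at 1 uM (a lower number here means slower removal, a higher number faster removal of the compound), and they spread widely. Compound 1 `Nc1ccc(S(=O)(=O)N2CCN(c3ncc(C(O)(C(F)(F)F)C(F)(F)F)cc3C#CCO)CC2)cn1` gives 65 mL.min-1.g-1 and compound 2 `Nc1ccc(S(=O)(=O)N2CCN(c3ncc(C(O)(C(F)(F)F)C(F)(F)F)cc3-c3cccnc3)CC2)cn1` gives 20 mL.min-1.g-1 while compound 3 `COc1ccc(-c2cc(C(O)(C(F)(F)F)C(F)(F)F)cnc2N2CCN(S(=O)(=O)c3ccc(N)nc3)CC2)cn1` gives 265 mL.min-1.g-1 as the highest of the three.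

Compound 4 `Nc1ccc(S(=O)(=O)N2CCN(c3ncc(C(O)(C(F)(F)F)C(F)(F)F)cc3-c3ccc4ocnc4c3)CC2)cn1` has not yet been measured. It differs from compound 3 by 1,3-benzoxazol-5-yl in place of 6-methoxypyridin-3-yl on an aromatic carbon with 1,3-benzoxazol-5-yl in place of 6-methoxypyridin-3-yl on an aromatic carbon.

The most relevant evidence is a 13-fold higher number from compound 2 to compound 3 (1.12 log units; beyond the scatter) with methoxy in place of hydrogen on an aromatic carbon, a large step. The two modest steps of a 3.3-fold lower number from compound 1 to compound 2 (0.51 log units; beyond the scatter) and a 4.1-fold higher number from compound 1 to compound 3 (0.61 log units; beyond the scatter) show that the group at this same place can move the number either way. Compound 4 has no methoxy group, which suggests a fall from compound 3. However, its new group is not the pyridin-3-yl of compound 2, so only part of the large step is expected to be reversed. The expected change is a 2.9-fold lower number from compound 3 to compound 4 (0.47 log units; beyond the scatter) in this assay and this estimate is uncertain. For compound 4 the estimated value is 90 mL.min-1.g-1 with an expected range from 30 mL.min-1.g-1 to 280 mL.min-1.g-1 until a measurement is available.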

Compound 4, intrinsic clearance in microsomes: 120 mL.min-1.g-1
Compound 4: the middle estimate sits 1.3-fold (0.12 log units) below what was measured, within the range that was stated.
By their numbers in this assay, from the lowest: compound 2; then compounds 1 and 4 (each within the scatter of the next); then compound 3.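

In this assay, the 1,3-benzoxazol-5-yl group of compound 4 carries no methoxy group, yet the number does not fall back to that of the plain pyridin-3-yl group: there is a 2.2-fold lower number from compound 3 to compound 4 (0.34 log units; beyond the scatter), but also a 6.0-fold higher number from compound 2 to compound 4 (0.78 log units; beyond the scatter). The absence of a methoxy group is therefore not enough to give a number as low as that of compound 2, and two aromatic groups without methoxy can differ clearly at this position. Compound 4 also cannot be told apart from compound 1, with a 1.8-fold higher number from compound 1 to compound 4 (0.27 log units; within the scatter), even though 1,3-benzoxazol-5-yl and 3-hydroxyprop-1-yn-1-yl are very different groups, and no measurement here explains any of these differences.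

On these data alone, the effect of adding a methoxy group rests on a single pair of compounds, so it remains open whether a methoxy group on another aromatic group, such as 1,3-benzoxazol-5-yl, would also raise the number. A further open question is whether a simple amine or a carboxylic acid on this aromatic carbon would give a lower number than that of compound 2. In this assay compound 2 gives 20 mL.min-1.g-1.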